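This account rests on a few compounds, and the source may have more. Where it says the series, first, only, none or still open, it means among the compounds named here.

Measured compounds and their half-life values:

compound 1, `CC(=O)OCc1cc(N)c(Nc2ccc(C#N)cc2)cc1Oc1c(C)cc(CCC#N)cc1C`, 0.17 h
compound 2, `Cc1cc(CCC#N)cc(C)c1Oc1cc(Nc2ccc(C#N)cc2)c(N)cc1COC(=O)C1CC1`, 0.195 h
compound 3, `COC(=O)c1cc(N)c(Nc2ccc(C#N)cc2)cc1Oc1c(Br)cc(CCC#N)cc1OC`, 2.32 h

In an ADME assay on liver for metabolic stability, with Liver microsome (Homo sapiens) as the target, read by LC-MS, using microsomes, tested at 1 uM (a lower number here means that the compound disappears faster, a higher number that the compound lasts longer), compound 3 gives 2.32 h, the highest number of the three; compound 2 gives 0.195 h and compound 1 gives 0.17 h, both far lower than compound 3 and beyond the scatter. Among the compounds with values here, no step is recorded between compound 3 and either of the other two, since they differ in more than one place.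

Compound 4, `CNC(=O)c1cc(N)c(Nc2ccc(C#N)cc2)cc1Oc1c(Br)cc(CCC#N)cc1OC`, differs from compound 3 by methylamino in place of methoxy on a carbonyl carbon; cut one bond further out, this reads methoxycarbonyl to methylcarbamoyl.

Within the data shown here, the only recorded step, a 1.1-fold higher number from compound 1 to compound 2 (0.06 log units; within the scatter), also sits on a carbonyl carbon, but it swaps a methyl for a cyclopropyl and says nothing about an ester becoming an amide. Among the measured compounds shown here, no measured pair covers the present change, so the expectation rests on compound 3 alone and carries a wide range. A step of about a 1.2-fold higher number from compound 3 to compound 4 (0.08 log units; within the scatter) is expected, that is, no clear change beyond the scatter, with room in both directions.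

For compound 4 in this assay a half-life of 2.8 h is estimated, between 1 h and 8 h.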

Compound 4, half-life in the Liver microsome assay: 2.32 h
Estimate against measurement, compound 4: 1.2-fold (0.08 log units) above; measured number inside the range.
By their numbers in the Liver microsome assay, from the lowest: compounds 1 and 2 (each within the scatter of the next); then compounds 3 and 4 (each within the scatter of the next).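

In the Liver microsome assay, methylamino in place of methoxy on this carbonyl carbon gives no change at the digits printed from compound 3 to compound 4 (within the scatter), so this read-out does not separate the methoxycarbonyl and methylcarbamoyl groups. In a physicochemical assay for solubility, read by HPLC, with a stated time of 4 h, at pH 2, tested at 10 mg/mL (on this read-out higher numbers stand for higher solubility and lower numbers for lower solubility), compound 3 gives 1.73 ug/mL and compound 4 gives 25.8 ug/mL. Within the data shown here, in the physicochemical assay, the same change gives a 15-fold higher number from compound 3 to compound 4 (1.17 log units; beyond the scatter), a separation that the methyl to cyclopropyl step between the earlier compounds, made on a different carbonyl carbon, could not have suggested. In this single pair, the methylcarbamoyl group therefore goes with higher solubility and an unchanged half-life: the measured solubility of compound 3, 1.73 ug/mL, and of compound 4, 25.8 ug/mL, a 15-fold higher number (1.17 log units; beyond the scatter)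

As far as these compounds go, it remains open whether a dimethylcarbamoyl group or a carboxylic acid in place of the methylcarbamoyl group would hold the half-life of compound 4 in the Liver microsome assay and its solubility in the physicochemical assay. From the compounds shown here alone, it also remains open whether the exchange of methoxy for methylamino reads the same way on a core other than that of compound 3.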